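A Chloromethyl Group Replaces the Phenyl

This account rests on a few compounds, and the source may have more. Where it says the series, first, only, none or still open, it means among the compounds named here.

Measured compounds:
compound 1 `CCCC(=O)CC/C=C/C=C/C#CC#C/C=C/COC(C)=O`: > 30000 nM (a limit)
compound 2 `CCCC(=O)CC/C=C/C=C/C#CC#C/C=C/COC(=O)c1ccccc1`: 7900 nM

Among the measured compounds shown here, in a functional assay on HT-29 cells (Homo sapiens) for cytotoxicity, read by sulforhodamine B assay, with a stated time of 96 h (a lower number here means that less compound is needed, a higher number that more compound is needed for the effect), compound 2 gives 7900 nM, the only true number so far. Compound 1 gives > 30000 nM, which is a limit of the assay.

The next compound, compound 3 `CCCC(=O)CC/C=C/C=C/C#CC#C/C=C/COC(=O)CCl`, keeps the shared core and differs from compound 2 in one place: chloromethyl in place of phenyl on a carbonyl carbon. This puts chloromethyl in place of phenyl on a carbonyl carbon.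

For the measured compounds named here, one measured step bears on this change: an at least 3.7-fold lower number from compound 1 to compound 2 (0.57 log units; beyond the scatter), with phenyl in place of methyl on a carbonyl carbon. Its size is tied to the limit of > 30000 nM in this assay, at which 1 of the 2 values shown sits.

Compound 3 gives up that phenyl, and the entering chloromethyl, like the methyl of compound 1, has no ring. A move to a higher number in this assay is therefore expected, back toward compound 1, of a size similar to or smaller than that measured step. Going by the values given here, no measured compound yet carries chlorine, so the range stays wide.

The expected change is a 2.3-fold higher number from compound 2 to compound 3 (0.36 log units; beyond the scatter). For compound 3 the estimated value is 18000 nM, with an expected range of 4000 nM to 30000 nM.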

Compound 3, half-maximal effective concentration: > 30000 nM
Compound 3 was reported as a limit (the forecaster's own chance of this, stated with the estimate: 35%); at least 1.6-fold (0.22 log units) between middle value and limit.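

In this assay, chloromethyl in place of phenyl on a carbonyl carbon brings an at least 3.7-fold higher number from compound 2 to compound 3 (0.57 log units; beyond the scatter), so a second group without a ring now joins the methyl of compound 1 in losing the measurable effect of compound 2. Among the three compounds, the phenyl of compound 2 is thus the only group at this position that gives a true number, and adding a chlorine to the methyl does not restore one. Any effect of chloro in place of hydrogen on the saturated chain carbon cannot be read from compound 1 to compound 3, because both values are limits: the limit of > 30000 nM in this assay, at which 2 of the 3 values shown sit.

The compounds shown leave open whether the gain at this position needs the aromatic ring itself or only a group of similar size, a question that a cyclohexyl group or a longer chain would address. They also leave open whether the phenyl can be improved on, as a chlorophenyl or a pyridyl ring might show, and how far compound 1 and compound 3 lie from each other beyond their shared limit.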